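Pyridazinone anilides: aryl swap at the ring nitrogen

A few compounds are considered here, and "the series" means these few. Any claim that something is new, unique, unknown or untested is made for them only; others in the source may bear on it.

Measured compounds:
compound 1 `Cc1cc(=O)n(-c2ccc(Br)cc2F)nc1C(=O)Nc1ccc(Oc2ncnc3ccsc23)cc1` — 7930 nM
compound 2 `Cc1cc(=O)n(-c2ccc(F)c(F)c2)nc1C(=O)Nc1ccc(Oc2ncnc3ccsc23)c(F)c1` — 4590 nM
compound 3 `Cc1cc(=O)n(-c2ccc(Br)cc2F)nc1C(=O)Nc1ccc(Oc2ncnc3sccc23)cc1` — 12800 nM

In a functional assay on A549 cells (Homo sapiens) for cytotoxicity, read by MTT assay, with a stated time of 72 h (a higher number here means a weaker inhibitor, a lower number a stronger inhibitor), compound 3 gives the highest of the three numbers; compound 1 lies nearest, and compound 2 furthest, beyond the scatter. Compound 4 `Cc1cc(=O)n(-c2ccc(F)c(F)c2)nc1C(=O)Nc1ccc(Oc2ncnc3sccc23)cc1` carries 3,4-difluorophenyl in place of 4-bromo-2-fluorophenyl on an aromatic nitrogen. Within the data shown here, the one single-place step measured, a 1.6-fold higher number from compound 1 to compound 3 (0.21 log units; within the scatter), concerns the bicyclic ether and not this aryl group. Compound 2 carries the same 3,4-difluorophenyl but differs from compound 1 in two places; in this assay compound 1 gives 7930 nM and compound 2 gives 4590 nM, a gap within the scatter. For compound 4 a step of a 1.3-fold lower number from compound 3 to compound 4 (0.13 log units; within the scatter) is therefore expected, not beyond the scatter. Compound 4 is estimated at 9500 nM, within 3500 nM to 26000 nM.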

Compound 4, half-maximal inhibitory concentration: 13500 nM
The estimate for compound 4 lay 1.4-fold (0.15 log units) below the measured number; measured number inside the range.
By their numbers in this assay, from the lowest: compounds 2, 1, 3 and 4 (each within the scatter of the next, the first and the last beyond it).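

In this assay, among these compounds, 3,4-difluorophenyl in place of 4-bromo-2-fluorophenyl on the aromatic nitrogen gives a 1.1-fold higher number from compound 3 to compound 4 (0.02 log units; within the scatter), the first single-place reading of this aryl swap. On the core of compound 3, this assay therefore does not separate the two aryl groups at this position. No measurement at hand accounts for this result. Going by these compounds, whether an amine or a carboxylic acid on this phenyl ring, or an alkyl chain in its place, would move the number beyond the scatter stays open. So does whether the swap reads the same on the core of compound 1.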